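The compounds below may be only part of what the source reports. "The series", "measured", "known", "first", "only" and "open" are said of these compounds alone.

Compound 3, `CC(=O)OCC(CCn1cc(C#Cc2ccc(Br)cc2)c(=O)n(C(=O)c2ccccc2)c1=O)COC(C)=O`, is the second of two aryl-capped alkynes in this set. In a functional assay on HeLa cells (Homo sapiens) for antiproliferative activity, read by MTT assay, with a stated time of 72 h (a higher number here means a weaker inhibitor, a lower number a stronger inhibitor), compound 3 gives 47200 nM, the lowest of the two numbers recorded. Its closest neighbour is compound 2, `CC(=O)OCC(CCn1cc(C#Cc2cc(F)cc(F)c2)c(=O)n(C(=O)c2ccccc2)c1=O)COC(C)=O`, which in this assay gives 64500 nM; the change a 1.4-fold lower number from compound 2 to compound 3 (0.14 log units; within the scatter) leaves the two within the scatter, so neither can be called the stronger. Compound 1, `O=c1[nH]c(=O)n(CCC(CO)CO)cc1-c1ccco1`, gives in this assay only a limit, > 100000 nM, as recorded in the limit of > 100000 nM in this assay, at which 1 of the 3 values shown sits.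

Compound 4, `CCCCCC#Cc1cn(CCC(COC(C)=O)COC(C)=O)c(=O)n(C(=O)c2ccccc2)c1=O`, departs from compound 3 by the change (pentyl in place of 4-bromophenyl on a triple-bonded carbon). Going by the values given here, the only measured step that touches the same position, the swap from compound 2 to compound 3, exchanges one aryl ring for another and stays within the scatter; no measured step exchanges an aryl ring for an alkyl chain, so the new step rests on weaker ground. Among the compounds with values here, with the one relevant step inside the scatter, the expected change for compound 4 is also none beyond the scatter, with the range widened for the uncertainty. For compound 4 the estimated value in this assay is 55000 nM, from 20000 nM to 150000 nM. This expectation means a step of a 1.2-fold higher number from compound 3 to compound 4 (0.07 log units; within the scatter).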

Compound 4, half-maximal inhibitory concentration: 53700 nM
Estimate against measurement, compound 4: 1.0-fold (0.01 log units) above; measured number inside the range.
By their numbers in this assay, from the lowest: compounds 3, 4 and 2 (each within the scatter of the next). At a limit, above all of these: compound 1.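

The steps of a 1.1-fold higher number from compound 3 to compound 4 (0.06 log units; within the scatter) and a 1.2-fold lower number from compound 2 to compound 4 (0.08 log units; within the scatter) both replace an aromatic ring with an open pentyl chain on a triple-bonded carbon. Going by these compounds alone, until now, the only comparison at this place had been between one aryl ring and another, whereas compound 4 shows that a group with no ring and fewer heavy atoms also leaves the number in this assay within the scatter, so across compounds 2, 3 and 4 the number does not track the presence of an aromatic ring. Nothing in the data shown bears on why these three values lie so close together.

The compounds shown leave open whether an amine or a carboxylic acid at the far end of the chain, or a chain longer than pentyl, on the same triple-bonded carbon would move the number beyond the scatter. Also open, from the compounds shown here alone, is whether a small methyl group, or a phenyl ring carrying an amine, would stay level with compounds 2, 3 and 4 in this assay or fall well away from them.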